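Aryl change on the shared core, compound 3 to compound 4

A few compounds are considered here, and "the series" means these few. Any claim that something is new, unique, unknown or untested is made for them only; others in the source may bear on it.

In a functional assay on HCT-116 cells (Homo sapiens) for inhibition, read by sulforhodamine B assay, with a stated time of 72 h (a higher number here means a weaker inhibitor, a lower number a stronger inhibitor), compound 3 (`COc1ccc2cc(C(C)c3nnc4n3N=C(c3ccc(Cl)cc3Cl)CS4)ccc2c1`) gives 14000 nM. Compound 1 (`COc1ccc2cc(C(C)c3nnc4n3N=C(c3ccc(Br)cc3)CS4)ccc2c1`) gives 11700 nM, which is within the scatter of compound 3. Only compound 2 (`CC(c1ccc(-c2ccccc2)c(F)c1)c1nnc2n1N=C(c1ccc(Cl)cc1Cl)CS2`), at 6900 nM, stands lower than compound 3 by more than the scatter.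

Compound 4 (`COc1ccc(C2=Nn3c(nnc3C(C)c3ccc4cc(OC)ccc4c3)SC2)cc1`) differs from compound 3 in one place: 4-methoxyphenyl in place of 2,4-dichlorophenyl on a carbon with a double bond to nitrogen. The 4-methoxyphenyl enters on a carbon with a double bond to nitrogen, and the 2,4-dichlorophenyl leaves.

Among the measured compounds shown here, one measured step bears on this place: a 1.2-fold higher number from compound 1 to compound 3 (0.08 log units; within the scatter). That exchange of 4-bromophenyl for 2,4-dichlorophenyl stays within the scatter. For the measured compounds named here, it is a single step, and no measured compound yet carries 4-methoxyphenyl here, so the evidence is thin and the range has to stay wide. On the strength of that one step, no change beyond the scatter is expected in this assay, with perhaps a slight drift towards the values of compound 1 and compound 3 taken together.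

The expected step is a 1.2-fold lower number from compound 3 to compound 4 (0.07 log units; within the scatter), which would lie within the scatter. For compound 4 the estimated value is 12000 nM, with an expected range of 5000 nM to 30000 nM.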

Compound 4, half-maximal inhibitory concentration: 6500 nM
Compound 4: middle estimate off by 1.8-fold (0.27 log units), on the high side; the measured number falls inside the stated range.
By their numbers in this assay, from the lowest: compounds 4, 2, 1 and 3 (each within the scatter of the next, the first and the last beyond it).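

In this assay, the aryl group on a carbon with a double bond to nitrogen now gives a step beyond the scatter, a 2.2-fold lower number from compound 3 to compound 4 (0.33 log units; beyond the scatter), whereas the earlier exchange at this place, a 1.2-fold higher number from compound 1 to compound 3 (0.08 log units; within the scatter), stayed within it. Among the compounds shown here, the new step is modest, and the methoxy for bromo exchange gives a 1.8-fold lower number from compound 1 to compound 4 (0.26 log units; within the scatter), which also stays within the scatter, so only the pair of 2,4-dichlorophenyl and 4-methoxyphenyl separates at this place. Nothing available gives a reason for this step.

Still open, on these data alone, is whether an amine or a carboxylic acid on this aryl ring would move the number further than 4-methoxyphenyl does, as the aryl groups compared so far carry only halogens or methoxy. Also open, as far as these compounds go, is whether the exchange of 2,4-dichlorophenyl for 4-methoxyphenyl gives a similar step on the core of compound 2, where the other substituent differs from that of compound 3 and compound 4.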